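A new side group on a compound at the assay limit

The source may hold more compounds than are shown below. What is called first, only, known or untested is meant among the compounds shown, and "the series" means these compounds.

In a functional assay on FaDu cells (Homo sapiens) for inhibition, read by sulforhodamine B assay (on this read-out lower numbers stand for stronger inhibition and higher numbers for weaker inhibition), compound 1 (`COC(=O)CC/C(C)=C/Cc1c(OC)c(C)c2c(c1OCC#CCN1CCCc3ccccc31)C(=O)OC2`) gives > 50000 nM as its reading, which is a limit of the assay and not a number. Compound 2 (`COC(=O)CC/C(C)=C/Cc1c(OC)c(C)c2c(c1OCC#CCN1CCC(Cc3ccccc3)CC1)C(=O)OC2`) gives > 50000 nM as its reading, again a limit. So all that is known so far is the limit of > 50000 nM in this assay, at which 2 of the 2 values shown sit, and no graded number to compare.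

Compound 3 (`CCCCNc1ccc(CC#CCOc2c(C/C=C(\C)CCC(=O)OC)c(OC)c(C)c3c2C(=O)OC3)cc1`) keeps the shared core and alters one group, with 4-(butylamino)phenyl in place of 1,2,3,4-tetrahydroquinolin-1-yl on a saturated chain carbon bound to a triple-bonded carbon. Going by the values given here, no measured step shows what such an exchange does. The expectation therefore starts from compound 1 at > 50000 nM which is a limit, and from nothing finer. The expected change (a number no higher from compound 1 to compound 3 (the limit leaves the size open)) is none beyond the scatter, in neither direction, and a reading at the same limit is quite likely. In this assay the estimated value for compound 3 is 50000 nM (expected range 15000 nM to 100000 nM).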

Compound 3, half-maximal inhibitory concentration: 21200 nM
Compound 3: middle estimate off by 2.4-fold (0.37 log units), on the high side, and the stated range covers the measured number.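

In this assay, putting 4-(butylamino)phenyl in place of 1,2,3,4-tetrahydroquinolin-1-yl on a saturated chain carbon bound to a triple-bonded carbon gives an at least 2.3-fold lower number from compound 1 to compound 3 (0.37 log units; beyond the scatter). This shows what compounds 1 and 2 alone could not: a change at this place can bring the reading off the limit. Going by these compounds alone, compound 3, at 21200 nM, provides the first graded number from which later changes can be measured. That number still stands alone, and the step from compound 1 has only a minimum size, since most readings shown give no graded value: the limit of > 50000 nM in this assay, at which 2 of the 3 values shown sit.

The exchange alters several things at once, removing the non-aromatic ring and adding a hydrogen-bond donor and a butyl chain, so the compounds shown cannot say which of these matters for the reading. A 4-aminophenyl group without the butyl chain, or a 4-(hexylamino)phenyl group with a longer chain, would help to separate these parts and show whether the length of the chain has any bearing on the number in this assay.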